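The source may hold more compounds than are shown below. What is called first, only, known or untested is meant among the compounds shown, and "the series" means these compounds.

Working notes on the series. Compound 1 `CC(C(=O)N1CCN(c2ccccc2)CC1)N1C(=O)CCC1=O` is the parent; in a functional assay on the whole organism (strain Swiss) with Mus musculus as the target, in the maximal electroshock model, with a stated time of 0.5 h, at a dose of 100 mg/kg by the intraperitoneal route (a lower number here means a weaker effect, a higher number a stronger effect of the compound at the dose given), compound 1 gives 0%. Compound 2 `CC(C(=O)N1CCN(c2ccc(F)cc2)CC1)N1C(=O)CCC1=O` carries fluoro in place of hydrogen on an aromatic carbon, and in this assay compound 2 gives 0%; the step of no change at the digits printed from compound 1 to compound 2 (within the scatter) is flat. Compound 3 `CC(C(=O)N1CCN(c2cccc(C(F)(F)F)c2)CC1)N1C(=O)CCC1=O` carries trifluoromethyl in place of hydrogen on an aromatic carbon, and in this assay compound 3 gives 75%; the step of a number 75 percentage points higher from compound 1 to compound 3 (beyond the scatter) is the one large movement in the set, and compound 3 stands highest of the three, beyond the scatter from both compound 1 and compound 2.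

Compound 4 `CC(C(=O)N1CCN(c2cccc(Cl)c2)CC1)N1C(=O)CCC1=O` is not yet measured. It differs from compound 3 by chloro in place of trifluoromethyl on an aromatic carbon. Among the compounds with values here, no measured step bears directly on this exchange; the only informative step, a number 75 percentage points higher from compound 1 to compound 3 (beyond the scatter), shows that a substituent at this place can carry the whole effect, while nothing shows whether chloro does so as fully as trifluoromethyl. The estimate for compound 4 in this assay is therefore a moderate loss, a number 25 percentage points lower from compound 3 to compound 4 (beyond the scatter), with wide uncertainty. Compound 4 is expected to give 50%, within a range of 0% to 100%.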

Compound 4, a percentage reported as activity, at one dose (the size of the read-out at that dose, not a potency): 75%
Estimate against measurement, compound 4: 25 percentage points below; measured number inside the range.
By their numbers in this assay, from the lowest: compounds 1 and 2 (each within the scatter of the next); then compounds 3 and 4 (each within the scatter of the next).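

In this assay, the step of no change at the digits printed from compound 3 to compound 4 (within the scatter) shows that the effect at this place, on an aromatic carbon meta to a large group, is not tied to trifluoromethyl: chloro, with 1 heavy atom against 4, serves as well within the scatter. The steps of a number 75 percentage points higher from compound 1 to compound 4 (beyond the scatter) and a number 75 percentage points higher from compound 2 to compound 4 (beyond the scatter) give chloro the same large separation from the two inactive compounds, so two different substituents now carry the effect, while the fluoro of compound 2 goes against any reading that covers every halogen on this ring. Nothing at hand gives a reason for these steps.

The compounds shown leave open whether the silence of compound 2 belongs to fluoro itself or to the place it occupies. They also leave open how far the tolerance at this aromatic carbon extends, for example to methoxy, an amine or a carboxylic acid.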